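A few compounds are considered here, and "the series" means these few. Any claim that something is new, unique, unknown or untested is made for them only; others in the source may bear on it.

Measured so far in a functional assay on SGC-7901 cells (Homo sapiens) for antiproliferative activity, read by MTT assay, with a stated time of 24 h; a higher number here means a weaker inhibitor, a lower number a stronger inhibitor:
- compound 1, `O=C(NNc1ccccc1Cl)c1ccc(NS(=O)(=O)c2cnc(O)nc2O)cc1`: 3630 nM
- compound 2, `Cc1ccccc1C(=O)NNC(=O)c1ccc(NS(=O)(=O)c2cnc(O)nc2O)cc1`: > 20000 nM

Compound 1 gives a measured number in this assay. For compound 2 the value is not a number but the limit of this assay, (the limit of > 20000 nM in this assay, at which 1 of the 2 values shown sits). On the numbers shown, compound 2 therefore stands at the weak end, and the step of an at least 5.5-fold higher number from compound 1 to compound 2 (0.74 log units; beyond the scatter) is the only measured step; it arises from (2-methylphenyl)carbonyl in place of 2-chlorophenyl on an amine nitrogen.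

Compound 3, `O=C(NNC(=O)c1ccc(NS(=O)(=O)c2cnc(O)nc2O)cc1)c1ccc(F)cc1`, is not yet measured. It differs from compound 2 by 4-fluorophenyl in place of 2-methylphenyl on a carbonyl carbon. For the measured compounds named here, no measured step swaps one aryl substituent for another on that carbonyl carbon, so the single step from compound 1 to compound 2 bears only loosely on this change. The expected step is a step that the limit leaves unreadable from compound 2 to compound 3, within the scatter. Compound 3 is therefore estimated at 25000 nM, with a range from 8000 nM to 80000 nM, most likely again only a limit.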

Compound 3, half-maximal inhibitory concentration: > 20000 nM
Compound 3: a limit, no number; the forecaster's own chance of this, stated with the estimate: 60%; the middle value does not contradict the limit.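

In this assay, compound 3 gives only a limit, and so does compound 2, so the swap of 2-methylphenyl for 4-fluorophenyl on the carbonyl carbon cannot be read as a step: the limit of > 20000 nM in this assay, at which 2 of the 3 values shown sit. Even so, (4-fluorophenyl)carbonyl in place of 2-chlorophenyl on the amine nitrogen gives an at least 5.5-fold higher number from compound 1 to compound 3 (0.74 log units; beyond the scatter), so the weak result of compound 2 is not tied to the 2-methylphenyl group alone. Of the three compounds, only compound 1, which has no carbonyl at this place, gives a measured number.

The compounds shown do not separate the effect of that added carbonyl from the effect of the change of aryl group, which a (2-chlorophenyl)carbonyl group would do. On these data alone, it also stays open whether an acetyl group at this place, or an amine on the aryl ring, would give a measured number.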